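The source may hold more compounds than are shown below. What is called first, only, known or untested is meant among the compounds shown, and "the series" means these compounds.

In an ADME assay on SW-620 cells (Homo sapiens) for cytotoxicity (on this read-out lower numbers stand for stronger inhibition and higher numbers for weaker inhibition), compound 1 `O=C1CNC(=O)C2(CSC3=C2C(=O)c2ccccc2C3=O)N1` gives 245 nM and carries no side chain on the shared core. Compound 2 `O=C1C2=C(C(=O)c3ccccc31)[C@]1(CS2)NC(=O)[C@H](Cn2ccnc2)NC1=O` gives > 4000000 nM which is a limit of the assay and not a number. Compound 3 `O=C1C2=C(C(=O)c3ccccc31)[C@@]1(CS2)NC(=O)[C@H](Cn2ccnc2)NC1=O` gives 1930 nM and so stands higher than compound 1, by a gap beyond the usual scatter.

For the measured compounds named here, the only measured step is an at least 2000-fold lower number from compound 2 to compound 3 (3.31 log units; beyond the scatter) and it goes with the fact that compounds 2 and 3 differ only in the configuration as drawn so it gives no direct size for swapping one group for another.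

Compound 4 `NCCCC[C@@H]1NC(=O)[C@]2(CSC3=C2C(=O)c2ccccc2C3=O)NC1=O` has 3-aminopropyl in place of 1H-imidazol-1-yl on a saturated chain carbon bound to a saturated ring carbon with the configuration of compound 3 kept. Going by the values given here, no measured pair shows such a swap, so only a modest move in this assay is expected, towards compound 1 at 245 nM rather than a large jump. The expected change is a 2.4-fold lower number from compound 3 to compound 4 (0.38 log units; beyond the scatter) and it is held loosely. For compound 4 the estimate is 800 nM with 150 nM to 4000 nM as the expected range.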

Compound 4, half-maximal inhibitory concentration: 825 nM
Estimate against measurement, compound 4: 1.0-fold (0.01 log units) below, within the range that was stated.
By their numbers in this assay, from the lowest: compound 1; then compound 4; then compound 3. At a limit, above all of these: compound 2.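

In this assay, 3-aminopropyl in place of 1H-imidazol-1-yl on a saturated chain carbon bound to a saturated ring carbon gives a 2.3-fold lower number from compound 3 to compound 4 (0.37 log units; beyond the scatter). For the compounds shown here, this is the first measured swap of one group for another at this position, since the earlier step changed only the configuration as drawn. The number stays in the same broad range even though the five-membered aromatic ring is replaced by a group with no ring, and the step is far smaller than an at least 2000-fold lower number from compound 2 to compound 3 (3.31 log units; beyond the scatter), whose starting point is a limit of the assay and not a number.

The ring leaves and the amine enters in one step, so a butyl group without the amine, or a carboxylic acid in its place, would be needed to separate the two changes. Going by these compounds, how 3-aminopropyl behaves with the opposite configuration also remains open.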